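From ethyl to hydroxymethyl on a shared core

The compounds below may be only part of what the source reports. "The series", "measured", "known", "first", "only" and "open" are said of these compounds alone.

In a functional assay on HCT-116 cells (Homo sapiens) for antiproliferative activity, read by CCK-8 assay and cell counting, with a stated time of 72 h (a higher number here means a weaker inhibitor, a lower number a stronger inhibitor), compound 3 `CCc1ccc(C(=O)Nc2ccccc2)cc1` gives > 100000 nM, which is a limit and not a number. Its two measured relatives both give numbers. Compound 1 `O=C(Nc1ccccc1)c1ccc(CCl)cc1` gives 1200 nM, and compound 2 `O=C(Nc1ccccc1)c1ccc(CO[N+](=O)[O-])cc1` gives 600 nM. These two do not separate, with a 2.0-fold lower number from compound 1 to compound 2 (0.30 log units; within the scatter).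

Compound 4 `O=C(Nc1ccccc1)c1ccc(CO)cc1` changes compound 3 at one place: hydroxy in place of methyl on a saturated chain carbon bound to an aromatic carbon. The same difference, cut one bond further out, reads ethyl to hydroxymethyl.

Going by the values given here, two measured steps touch that same place, both ending at methyl. For compound 1 the step is an at least 83-fold higher number from compound 1 to compound 3 (1.92 log units; beyond the scatter), and for compound 2 it is an at least 160-fold higher number from compound 2 to compound 3 (2.22 log units; beyond the scatter). Both are large, so methyl at this place stands apart from chloro and from nitrooxy. Read in reverse, they point to a lower number when methyl is replaced. Hydroxy, however, is neither of those two groups, so only part of that size is expected to return, and compound 4 could also stay at the limit. The expected step in this assay is an at least 6.6-fold lower number from compound 3 to compound 4 (0.82 log units; beyond the scatter). For compound 4 the estimate is 15000 nM, with an expected range from 2000 nM to 100000 nM.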

Compound 4, half-maximal inhibitory concentration: 24800 nM
Beside the measured number, compound 4's estimate is 1.7-fold (0.22 log units) below it; the range from low to high includes it.
By their numbers in this assay, from the lowest: compounds 2 and 1 (each within the scatter of the next); then compound 4. At a limit, above all of these: compound 3.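

In this assay, hydroxy in place of methyl lowers the number, with an at least 4.0-fold lower number from compound 3 to compound 4 (0.60 log units; beyond the scatter), but compound 4 remains far from the two earlier compounds, with a 41-fold higher number from compound 2 to compound 4 (1.62 log units; beyond the scatter) and a 21-fold higher number from compound 1 to compound 4 (1.32 log units; beyond the scatter). The earlier compounds shown here showed only that methyl stands apart from chloro and nitrooxy at this place; compound 4 shows that the position is graded rather than all-or-none, as a group other than those two can give a measured number here without coming close to theirs. The step from methyl can be read only as a bound, since compound 3 stands at a limit: the limit of > 100000 nM in this assay, at which 1 of the 4 values shown sits.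

The compounds shown leave open where an amine, a methoxy group or a carboxylic acid on the same saturated chain carbon would fall among these values. They also do not tell why hydroxy stands so far from chloro and nitrooxy, so the cause of these large steps remains unknown.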